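The source may report more compounds than this note shows. Statements on the series, on what has been measured and on what is new or still open speak of the compounds shown alone.

Measured in an ADME assay on HEp-2 cells (Homo sapiens) for cytotoxicity, read by MTT assay, with a stated time of 72 h; a higher number here means a weaker inhibitor, a lower number a stronger inhibitor:
Compound 1 `COc1ccc(C2=C(c3cc(OC)c(OC)c(OC)c3)C(=O)C(OC(C)=O)C2)cc1`: 18 ug/mL
Compound 2 `COc1cc(C2=C(c3cc(C)c(OC)c(C)c3)C(O)CC2=O)cc(OC)c1OC`: > 100 ug/mL (a limit)

In this assay compound 2 gives only a limit, > 100 ug/mL, so its true position is not known. Compound 3 `COc1cc(C2=C(c3cc(C)c(OC)c(C)c3)C(OC(C)=O)CC2=O)cc(OC)c1OC` differs from compound 2 by acetyl in place of hydrogen on an oxygen on a saturated carbon, that is, hydroxy to acetoxy. The expectation leans on compound 1, which also carries an acetoxy and gives 18 ug/mL. The expected step of an at least 2.0-fold lower number from compound 2 to compound 3 (0.30 log units; that floor lies within the scatter) runs toward a stronger inhibitor, moderately beyond the scatter. Compound 3 is estimated at 50 ug/mL, with an expected range of 15 ug/mL to 100 ug/mL.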

Compound 3, half-maximal inhibitory concentration: > 100 ug/mL
Compound 3: only a limit was reported (the forecaster's own chance of this, stated with the estimate: 35%); middle value at least 2.0-fold (0.30 log units) away from the limit.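

In this assay, going by these compounds alone, compound 3 gives > 100 ug/mL, a limit like that of compound 2, and no step between the two can be read: the limit of > 100 ug/mL in this assay, at which 2 of the 3 values shown sit. The compounds shown leave open where compound 2 and compound 3 truly lie, and whether hydroxy to acetoxy shifts the value at all.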